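Meta-nitro analogue in the aminothiophene ketone series

The source may hold more compounds than are shown below. What is called first, only, known or untested is meant among the compounds shown, and "the series" means these compounds.

Measured so far:
compound 1, `Nc1scc(-c2ccc(Br)cc2)c1C(=O)c1ccccc1`, 46%
compound 2, `Nc1scc(-c2ccc([N+](=O)[O-])cc2)c1C(=O)c1ccccc1`, 50%
compound 3, `Nc1scc(-c2cccc(Br)c2)c1C(=O)c1ccc(Cl)cc1`, 62%

In a functional assay on CHO cells for agonist activity at adenosine receptor A1 (Homo sapiens), read by fluorescence and ERK phosphorylation, with stated times of 30 min and 1.5 h, tested at 3 uM (on this read-out higher numbers stand for a stronger effect at the one concentration tested and lower numbers for a weaker effect), compound 1 gives 46% and compound 2 gives 50%. The change between them is nitro in place of bromo on an aromatic carbon, and the step is a number 4 percentage points higher from compound 1 to compound 2 (within the scatter). Compound 3 gives 62% in this assay, the highest of the three; the difference between its core and that of compound 1 is not broken down here.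

Compound 4, `Nc1scc(-c2cccc([N+](=O)[O-])c2)c1C(=O)c1ccc(Cl)cc1`, is not yet measured. It differs from compound 3 by nitro in place of bromo on an aromatic carbon, the same kind of change as from compound 1 to compound 2, the group now sitting meta to a large group rather than para to a large group. Because the earlier step was a number 4 percentage points higher from compound 1 to compound 2 (within the scatter), the step from compound 3 to compound 4 is expected to be small, a number 2 percentage points higher from compound 3 to compound 4 (within the scatter). Compound 4 is therefore estimated at 64% in this assay, between 50% and 78%.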

Compound 4, a percentage reported as activity, at one concentration (the size of the read-out at that concentration, not a potency): 53%
Beside the measured number, compound 4's estimate is 11 percentage points above it; the measured number falls inside the stated range.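

Nitro in place of bromo on an aromatic carbon gives, in this assay, a number 9 percentage points lower from compound 3 to compound 4 (within the scatter). Set beside the earlier step, the new one does not differ from it: the same change on two cores in this assay, a number 4 percentage points higher (within the scatter) from compound 1 to compound 2 and a number 9 percentage points lower (within the scatter) from compound 3 to compound 4, 13 percentage points apart, within the scatter of two such steps. This shows that, on these two cores, the change leaves no step beyond the scatter; it does not show that the change is without effect on other cores, and two single-concentration steps cannot separate an influence of the core from one of the group's place on the ring.

Still open, as far as these compounds go, is whether an amine or a carboxylic acid on the same aromatic carbon would read differently from bromo and nitro. Also open, from the compounds shown here alone, is how the change behaves on the core of compound 1 with the group meta to a large group.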